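The source may hold more compounds than are shown below. What is called first, only, known or untested is meant among the compounds shown, and "the series" means these compounds.

Measured so far:
- compound 1, `C[C@@H](O[C@@H]1[C@@H](c2ccc(F)cc2)CN2C(=O)OC[C@@H]12)c1cc(C(F)(F)F)cc(C(F)(F)F)c1`: 0.33 nM
- compound 2, `C[C@@H](O[C@H]1CN2C(=O)OC[C@@H]2[C@@H]1c1ccc(F)cc1)c1cc(C(F)(F)F)cc(C(F)(F)F)c1`: 0.14 nM

Two compounds have been run in an assay on CHO cells for displacement of a labelled ligand from Substance-P receptor (Homo sapiens); a higher number here means a weaker inhibitor, a lower number a stronger inhibitor. Compound 1 gives 0.33 nM, and compound 2 gives 0.14 nM. On these two numbers compound 1 stands at the higher end: its nearest neighbour is compound 2, whose value lies lower by a gap that is beyond the usual scatter of repeated runs. Among the measured compounds shown here, compound 2 is a configurational isomer of compound 1 sharing the same atoms and bonds, but no single-site step between the two is set out, so only their two values are put side by side here.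

The step followed now leads from compound 1 to compound 3, `C[C@@H](O[C@@H]1[C@@H](c2ccc(F)cc2)CN2C(=O)OC[C@H]12)c1cc(C(F)(F)F)cc(C(F)(F)F)c1`. The change is the two compounds have the same atoms and bonds and differ only in configuration as drawn: 1 of 4 stereo elements differ; a stereocentre at a saturated ring carbon is drawn S in compound 1 and R in compound 3: the two compounds have the same atoms and bonds and differ only in configuration as drawn, a stereocentre at a saturated ring carbon being drawn S in compound 1 and R in compound 3. For the measured compounds named here, no measured pair in this set shows what such an inversion does in this assay, so the size of the step cannot be read from the data. Inverting one ring stereocentre in a rigid bicyclic core is judged likely to move the number upward, toward weaker inhibition, by a step well beyond the scatter, though with a wide uncertainty. Compound 3 is therefore expected to show a 24-fold higher number from compound 1 to compound 3 (1.38 log units; beyond the scatter), landing at an estimated 8 nM with a range from 0.8 nM to 100 nM.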

Compound 3, half-maximal inhibitory concentration: 1 nM
Estimate against measurement, compound 3: 8.0-fold (0.90 log units) above; the range from low to high includes it.
By their numbers in this assay, from the lowest: compound 2; then compound 1; then compound 3.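

Inverting a stereocentre at a saturated ring carbon, from S to R, gives a 3.0-fold higher number from compound 1 to compound 3 (0.48 log units; beyond the scatter) in this assay, the only step in the set that isolates a single site. The earlier pair could not tie a change in the number to any one centre, whereas here the shift can be ascribed to this inversion alone, because nothing else separates the two structures: the fact that compounds 1 and 3 differ only in the configuration as drawn. The inversion weakens binding without abolishing it, as compound 3 still gives 1 nM, so the R configuration at this carbon is tolerated in this assay.

Among the compounds shown here, no single-site step connects compound 2 with the other two compounds, so its value cannot be read as the effect of inverting any one centre, and the contributions of the remaining stereo elements stay unresolved. On these data alone, it also remains open whether the same inversion would have a similar effect with a different group on the shared core, such as an amine or a carboxylic acid.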